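This account rests on a few compounds, and the source may have more. Where it says the series, first, only, none or still open, it means among the compounds named here.

Measured so far:
compound 1 `CC(C)n1nc(-c2cc(C3CCCCC3)on2)c2c(N)ncnc21` gives 9500 nM
compound 2 `Nc1ncnc2c1c(-c1cc(C3CC3)on1)nn2C1CCCCC1` gives 520 nM
compound 3 `CC(C)n1nc(/C=N/OCc2ccccc2)c2c(N)ncnc21` gives 7410 nM

In an assay on BaF3 cells for inhibition of proto-oncogene tyrosine-protein kinase receptor Ret (Homo sapiens), read by MTT assay, with a stated time of 48 h (on this read-out higher numbers stand for weaker inhibition of growth and lower numbers for stronger inhibition of growth), compound 1 stands at the highest of the three numbers. Compound 3 sits within the scatter of compound 1, so the two cannot be ordered. Compound 2 lies below compound 1 by a margin beyond the scatter, but compound 2 differs from compound 1 in two places, so only its value is known and no single step can be read from the pair.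

Compound 4 `CC(C)c1cc(-c2nn(C(C)C)c3ncnc(N)c23)no1` is not yet measured. Against compound 1 the change is isopropyl in place of cyclohexyl on an aromatic carbon. Going by the values given here, no single-point step between measured compounds exists in this set to guide the size. The expectation is a small step from compound 1 to compound 4, a 1.9-fold lower number from compound 1 to compound 4 (0.28 log units; within the scatter), toward stronger inhibition of growth, possibly not beyond the scatter. The estimate for compound 4 is 5000 nM, with a range from 1500 nM to 20000 nM.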

Compound 4, concentration for 50% growth inhibition: 2400 nM
Estimate against measurement, compound 4: 2.1-fold (0.32 log units) above; measured number inside the range.
By their numbers in this assay, from the lowest: compound 2; then compound 4; then compounds 3 and 1 (each within the scatter of the next).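

In this assay, going by these compounds alone, isopropyl in place of cyclohexyl on the aromatic carbon next to the ring oxygen gives a 4.0-fold lower number from compound 1 to compound 4 (0.60 log units; beyond the scatter), the first step that can be read at a single place. This position therefore responds to the group it carries, and here the group with no ring goes with stronger inhibition of growth. No measurement at hand bears on the reason for this step.

As far as these compounds go, whether a methyl or an aminomethyl group on this carbon would move the number further remains open. Within the data shown here, with only two groups compared at this position, no trend with group size can be stated.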